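This account rests on a few compounds, and the source may have more. Where it says the series, first, only, none or still open, it means among the compounds named here.

Measured compounds in a functional assay on MCF7 cells (Homo sapiens) for antiproliferative activity, read by sulforhodamine B assay, with a stated time of 48 h; a higher number here means a weaker inhibitor, a lower number a stronger inhibitor:
- compound 1, `O=C1NCCN1c1ccc(S(=O)(=O)Nc2cccc(Br)c2)cc1`: 100 nM
- compound 2, `O=C1NCCN1c1ccc(S(=O)(=O)Nc2ccc(OC(F)F)cc2)cc1`: 760 nM
- compound 3, `COc1cccc(NS(=O)(=O)c2ccc(N3CCNC3=O)cc2)c1`: 120 nM

Compound 2 gives the highest number of the three. Compound 3 gives a lower number, and compound 1 a lower number still; both gaps from compound 2 lie beyond the scatter. Within the data shown here, the one step between measured compounds, a 1.2-fold higher number from compound 1 to compound 3 (0.08 log units; within the scatter), concerns an exchange at the aniline ring that is within the scatter, and neither of its groups is the one that leaves or enters here.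

Compound 4, `CC(C)(C)c1ccc(NS(=O)(=O)c2ccc(N3CCNC3=O)cc2)cc1`, differs from compound 2 as follows: tert-butyl in place of difluoromethoxy on an aromatic carbon. Among the measured compounds shown here, no measured step involves a difluoromethoxy or a tert-butyl group, so no step speaks directly to this change. What remains is that the shared core of compound 1 and compound 3 carries a lower number than compound 2, which leaves room for compound 4 in either direction.

Compound 4 is therefore expected near compound 2, at 500 nM in this assay, with a range of 150 nM to 2000 nM; the expected step is a 1.5-fold lower number from compound 2 to compound 4 (0.18 log units; within the scatter).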

Compound 4, half-maximal inhibitory concentration: > 1000 nM
Compound 4 ended at the assay's limit; the forecaster's own chance of this, stated with the estimate: 5%; at least 2.0-fold (0.30 log units) between middle value and limit.
By their numbers in this assay, from the lowest: compounds 1 and 3 (each within the scatter of the next); then compound 2. At a limit, above all of these: compound 4.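

In this assay, compound 4 gives a limit of the assay and not a number: the limit of > 1000 nM in this assay, at which 1 of the 4 values shown sits.

For tert-butyl in place of difluoromethoxy on an aromatic carbon, para to a large group, the series now has its first reading at this position: an at least 1.3-fold higher number from compound 2 to compound 4 (0.11 log units; that floor lies within the scatter). On these data alone, the change therefore brings no measurable gain here, but the floor does not separate the two compounds beyond the scatter, and the true size of the step stays unknown.

The two groups have the same heavy-atom count and differ in hydrogen-bond acceptors, and the compounds shown leave open whether either feature matters at this position. Also open, as far as these compounds go, is how an amine or a carboxylic acid at the same place would read in this assay.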